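The source may hold more compounds than are shown below. What is called first, only, known or untested is meant among the compounds shown, and "the series" means these compounds.

In a functional assay on A549 cells (Homo sapiens) for inhibition, read by sulforhodamine B assay (on this read-out lower numbers stand for stronger inhibition and higher numbers for weaker inhibition), compound 1 (`COC(=O)CC/C(C)=C/Cc1c(OC)c(C)c2c(c1OCC#CCN1CCN(c3ccc(O)cc3)CC1)C(=O)OC2`) gives > 50000 nM, which is a limit of the assay. Compound 2 (`COC(=O)CC/C(C)=C/Cc1c(OC)c(C)c2c(c1OCC#CCN1CCN(Cc3ccc(Cl)cc3)CC1)C(=O)OC2`) gives > 50000 nM, also a limit, so it stands with compound 1 at the limit of > 50000 nM in this assay, at which 2 of the 2 values shown sit. The change to compound 3 (`COC(=O)CC/C(C)=C/Cc1c(OC)c(C)c2c(c1OCC#CCN1CCN(C(c3ccccc3)c3ccc(Cl)cc3)CC1)C(=O)OC2`) is phenyl in place of hydrogen on a saturated chain carbon bound to an amine nitrogen in a ring and an aromatic carbon. Going by the values given here, the only measured step, a step that the two limits leave unreadable from compound 1 to compound 2, gives no size to build on, so little change is expected in this assay, and any change would probably be towards slightly stronger inhibition. The expected move is an at least 1.2-fold lower number from compound 2 to compound 3 (0.09 log units; that floor lies within the scatter), a small one. For compound 3 the estimated value is 40000 nM, with an expected range of 12000 nM to 100000 nM.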

Compound 3, half-maximal inhibitory concentration: 29100 nM
Estimate against measurement, compound 3: 1.4-fold (0.14 log units) above; measured number inside the range.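

In this assay, going by these compounds alone, compound 3 gives 29100 nM, the only value shown that is not a limit of the assay: the limit of > 50000 nM in this assay, at which 2 of the 3 values shown sit. Phenyl in place of hydrogen on this saturated chain carbon brings an at least 1.7-fold lower number from compound 2 to compound 3 (0.23 log units; that floor lies within the scatter), so this position is the first shown to carry a readable number. On these data alone, compound 2 has only a limit, so the full size of this step remains unknown. The step between the two limits cannot be read. As far as these compounds go, whether a methyl or a cyclohexyl on this carbon would give a similar number to phenyl stays open.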